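The source may report more compounds than this note shows. Statements on the series, on what has been measured and on what is new or still open speak of the compounds shown alone.

Compounds measured so far:
- compound 1, `CC[C@@H]1C(=O)N(C)c2cnc(-n3ccc4cc(F)ccc43)nc2N1C1CCCC1`: 969 nM
- compound 2, `CCC1C(=O)N(C)c2cnc(-n3ccc4cc(C(N)=O)ccc43)nc2N1c1ccn(C)n1`: 384 nM
- compound 3, `CCC1C(=O)N(C)c2cnc(Nc3ccc(S(=O)(=O)NCC(C)C)cc3)nc2N1c1ccn(C)n1`: 311 nM

In an assay for inhibition of serine/threonine-protein kinase PLK2 (Homo sapiens), read by FRET and Z'-LYTE, with a stated time of 1 h (on this read-out higher numbers stand for weaker inhibition and lower numbers for stronger inhibition), compound 3 gives the lowest of the three numbers. Its neighbour on this read-out is compound 2, whose value in this assay sits within the usual scatter of that of compound 3, so no order can be read between these two. Compound 1 stands further off, beyond the scatter, with a higher number in this assay than compound 3.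

Compound 4, `CCC1C(=O)N(C)c2cnc(Nc3ccc(S(=O)(=O)NCCO)cc3)nc2N1c1ccn(C)n1`, has not yet been measured. It differs from compound 3 in one place: hydroxymethyl in place of isopropyl on a saturated chain carbon bound to a sulfonamide nitrogen. Both keep the shared core and the same aniline-linked sulfonamide arm; only the group on the sulfonamide nitrogen changes, isobutyl to 2-hydroxyethyl.

Among the measured compounds shown here, no step between measured compounds with this kind of change is available, so the expectation rests on the change itself. Compound 4 is expected to land close to compound 3 in this assay, with a step of a 1.3-fold higher number from compound 3 to compound 4 (0.11 log units; within the scatter) that stays within the scatter or at most slightly toward weaker inhibition. The estimate for compound 4 is 400 nM, with a range from 150 nM to 1100 nM.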

Compound 4, half-maximal inhibitory concentration: 478 nM
For compound 4 the middle estimate is 1.2-fold (0.08 log units) below the measured one; measured number inside the range.
By their numbers in this assay, from the lowest: compounds 3, 2 and 4 (each within the scatter of the next); then compound 1.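

In this assay hydroxymethyl in place of isopropyl on a saturated chain carbon bound to a sulfonamide nitrogen gives a 1.5-fold higher number from compound 3 to compound 4 (0.19 log units; within the scatter) and so leaves no order that can be read between the two compounds. This is the first pair shown that differs in one place, and it shows that at this position a group with a hydrogen-bond donor and acceptor can enter in place of one with neither, with the number staying within the scatter. No measurement bears on why the step is this size.

From the compounds shown here alone, whether the same holds for an amine, a carboxylic acid or a longer chain at this position stays open. Also open, going by these compounds, is whether this change would give a similar step on the arms or cores of compound 1 and compound 2.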